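The source may report more compounds than this note shows. Statements on the series, on what has been measured and on what is new or still open speak of the compounds shown alone.

Of the compounds shown here, two have been tested so far in a functional assay on PC-3 cells (Homo sapiens) for antiproliferative activity, read by MTT assay, with a stated time of 48 h; a higher number here means a weaker inhibitor of growth, a lower number a stronger inhibitor of growth. Compound 1, `COc1ccc(/C=C2\Cc3cc(OC)c(OC)c(OC)c3C2=O)cc1N`, gives only a limit there, namely > 10000 nM. Compound 1 thus sits at the limit of > 10000 nM in this assay, at which 1 of the 2 values shown sits. Among the compounds with values here, compound 2, `COc1ccc(/C=C2\CCc3c(cc(OC)c(OC)c3OC)C2=O)cc1`, gives 19600 nM in this assay, and that is the only plain number among the two results, so compound 2 is the one point from which an expectation can start.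

Compound 3, `COc1ccc(/C=C2\CCc3c(cc(OC)c(OC)c3OC)C2=O)cc1F`, has not yet been measured. It differs from compound 2 in one place: fluoro in place of hydrogen on an aromatic carbon. Put more broadly, the 4-methoxyphenyl group of compound 2 becomes a 3-fluoro-4-methoxyphenyl group in compound 3, the fluorine standing ortho to the methoxy group.

Within the data shown here, no pair of measured compounds shows what this swap does in this assay, so there is no measured step to lean on. Fluoro in place of hydrogen changes only one position, and with nothing to point either way the expected step is a 1.3-fold lower number from compound 2 to compound 3 (0.12 log units; within the scatter), within the scatter and with no direction favoured. Compound 3 is therefore estimated at 15000 nM, with a range from 5000 nM to 40000 nM.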

Compound 3, concentration for 50% growth inhibition: 27600 nM
The estimate for compound 3 lay 1.8-fold (0.26 log units) below the measured number; measured number inside the range.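

Fluoro in place of hydrogen on this aromatic carbon, ortho to a methoxy group, gives a 1.4-fold higher number from compound 2 to compound 3 (0.15 log units; within the scatter) in this assay, so this is the first measured step at this position of the 4-methoxyphenyl group. It shows that turning the 4-methoxyphenyl group into a 3-fluoro-4-methoxyphenyl group produces no shift that can be told apart from the ordinary spread of repeated measurements, and compound 2 and compound 3 remain in the same range of growth inhibition. Within the data shown here, nothing measured so far bears on why the step has this size, and a single small step gives no ground for a reason.

On these data alone, whether a chloro, a hydroxyl or a trifluoromethyl group on this same carbon would move the number beyond the scatter remains open, as does whether any change here matters more than changes elsewhere on the shared core. Among these compounds, compound 1 gives only the limit > 10000 nM and differs from compound 2 in more than one place, so it offers no step to set beside this one.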